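A chloro to fluoro swap among inactive amides

A few compounds are considered here, and "the series" means these few. Any claim that something is new, unique, unknown or untested is made for them only; others in the source may bear on it.

- compound 1 `COc1ccccc1NC(=O)c1cc(=O)[nH]c2cc(Br)ccc12` gives > 20000 nM as a limit
- compound 2 `O=C(Nc1ccc(Cl)cc1)c1cc(=O)[nH]c2cc(Br)ccc12` gives > 20000 nM as a limit

In a functional assay on KYSE-70 cells for antiproliferative activity against KYSE-70 cell line (Homo sapiens), read by MTT assay, with a stated time of 72 h (a lower number here means a stronger inhibitor, a higher number a weaker inhibitor), compound 2 stands at > 20000 nM and this is a limit, not a number. Within the data shown here, both measured compounds share the limit of > 20000 nM in this assay, at which 2 of the 2 values shown sit, and so give no measured step to go by. Compound 3 `O=C(Nc1ccc(F)cc1)c1cc(=O)[nH]c2cc(Br)ccc12` changes compound 2 in one place: fluoro in place of chloro on an aromatic carbon with fluoro in place of chloro on an aromatic carbon para to a large group. No change beyond the scatter is expected in this assay in either direction. The expected change is a number no higher from compound 2 to compound 3 (the limit leaves the size open) on this estimate. For compound 3 the expected value is 20000 nM within an estimated range from 8000 nM to 50000 nM in this assay's read-out.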

Compound 3, half-maximal inhibitory concentration: > 20000 nM
Compound 3: only a limit was reported; the forecaster's own chance of this, stated with the estimate: 75%; the middle value sits exactly at the limit.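

Compound 3, like compound 2, gives only a limit and no number, so no step between them can be read: the limit of > 20000 nM in this assay, at which 3 of the 3 values shown sit.

The compounds shown leave open how the 4-chlorophenyl and 4-fluorophenyl amides actually compare in this assay.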